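The source may report more compounds than this note shows. Statements on the series, on what has been measured and on what is new or still open speak of the compounds shown alone.

Compound 1 `COc1cc(NCc2ccccc2)cc(OC)c1OC` is the starting point here. In a functional assay on HCT-116 cells (Homo sapiens) for inhibition, read by MTT assay, with a stated time of 48 h (a lower number here means a stronger inhibitor, a higher number a weaker inhibitor), compound 1 gives > 80000 nM, which is a limit of the assay and not a number. Two amides give a sense of the numbers seen so far. In this assay compound 2 `COc1ccc(CN(C(=O)C(C)Br)c2cc(OC)c(OC)c(OC)c2)cc1O` gives 140 nM, and compound 3 `C/C=C/C(=O)N(Cc1ccc(OC)c(OC)c1)c1cc(OC)c(OC)c(OC)c1` gives 32800 nM. Going by the values given here, neither of these differs from compound 1 in one place alone, so no measured step shows what a single change does.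

Compound 4 `COc1cc(NCc2ccc(Br)cc2)cc(OC)c1OC` keeps the core of compound 1 and changes one thing: phenyl becomes 4-bromophenyl, with bromo in place of hydrogen on an aromatic carbon, para to a large group (bromo in place of hydrogen on an aromatic carbon). Like compound 1, it is not an amide. Among the compounds with values here, with only this small change and no measured step as a guide, no shift beyond the usual scatter is expected, and compound 4 may again be reported only as a limit. The expected step, a number no higher from compound 1 to compound 4 (the limit leaves the size open), is therefore a cautious estimate. It rests on compound 1, with its limit of > 80000 nM. The estimated value for compound 4 is 80000 nM, with an expected range of 30000 nM to 160000 nM.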

Compound 4, half-maximal inhibitory concentration: > 80000 nM
Compound 4: only a limit was reported (the forecaster's own chance of this, stated with the estimate: 65%); the middle value sits exactly at the limit.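

Compound 1 and compound 4 are both reported only as a limit in this assay, so no step can be read between them, because both stop at the same limit: the limit of > 80000 nM in this assay, at which 2 of the 4 values shown sit. The compounds shown leave open what bromo in place of hydrogen does when both compounds of a pair give a true number in this assay.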